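Fluoro to Trifluoromethyl: an Expected Gain in Cell Growth Inhibition

The source may hold more compounds than are shown below. What is called first, only, known or untested is meant among the compounds shown, and "the series" means these compounds.

Of the compounds shown here, two built on one shared core have been tested in a functional assay on MCF7 cells (Homo sapiens) for antiproliferative activity, read by MTT assay, with a stated time of 24 h; on this read-out lower numbers stand for stronger inhibition and higher numbers for weaker inhibition. Compound 1 `FC(F)(F)c1ccc(C2CC(c3ccc(Cl)cc3)=NN2c2ccc(-c3ccccc3)nn2)cc1` gives 1670 nM. Compound 2 `COc1ccc(C2=NN(c3ccc(-c4ccccc4)nn3)C(c3ccc(F)cc3)C2)cc1` gives 20000 nM, the higher of the two numbers and therefore the weaker inhibitor of cell growth. Compound 3 `COc1ccc(C2=NN(c3ccc(-c4ccccc4)nn3)C(c3ccc(C(F)(F)F)cc3)C2)cc1` differs from compound 2 by trifluoromethyl in place of fluoro on an aromatic carbon. Among the measured compounds shown here, no measured pair isolates this single change, so its size is uncertain. Compound 3 is expected to show a step of a 2.5-fold lower number from compound 2 to compound 3 (0.40 log units; beyond the scatter) in this assay, toward a lower number. Compound 3 is estimated at 8000 nM, in a range from 2000 nM to 30000 nM.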

Compound 3, half-maximal inhibitory concentration: 46800 nM
Compound 3: the middle estimate sits 5.9-fold (0.77 log units) below what was measured, outside the stated range (above it).
By their numbers in this assay, from the lowest: compound 1; then compound 2; then compound 3.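

In this assay, trifluoromethyl in place of fluoro does not strengthen growth inhibition at this position, para to a large group: the change gives a 2.3-fold higher number from compound 2 to compound 3 (0.37 log units; beyond the scatter). At the other changed place, methoxy in place of chloro gives a 28-fold higher number from compound 1 to compound 3 (1.45 log units; beyond the scatter), a large step against that modest one. No measurement shown gives a reason for either step. Still open, as far as these compounds go, is how an amine or a carboxylic acid in place of fluoro would read, and whether fluoro paired with chloro would give a lower number than compound 2.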